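Replacing a urea with an acyl sulfonamide on the shared core

The compounds below may be only part of what the source reports. "The series", "measured", "known", "first", "only" and "open" are said of these compounds alone.

Of the compounds shown here, three sharing one core have been measured in an assay on microsomes from brain for inhibition of Fatty-acid amide hydrolase 1 (Rattus norvegicus), read by fluorescence and HPLC, with a stated time of 45 min; on this read-out higher numbers stand for weaker inhibition and lower numbers for stronger inhibition. Compound 1, `O=C(COc1ccc(Oc2ccccc2)cc1)Cn1ncc2cc(C(=O)O)ccc21`, carries a carboxy group and gives 55 nM. Compound 2, `O=C(COc1ccc(Oc2ccccc2)cc1)Cn1ncc2cc(NC(=O)Oc3ccccc3)ccc21`, gives 2100 nM, and compound 3, `O=C(COc1ccc(Oc2ccccc2)cc1)Cn1ncc2cc(NC(=O)Nc3ccccc3)ccc21`, gives 6000 nM, the highest of the three numbers. The steps of a 38-fold higher number from compound 1 to compound 2 (1.58 log units; beyond the scatter) and a 110-fold higher number from compound 1 to compound 3 (2.04 log units; beyond the scatter) were both large, while a 2.9-fold higher number from compound 2 to compound 3 (0.46 log units; beyond the scatter) was modest.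

Compound 4, `O=C(COc1ccc(Oc2ccccc2)cc1)Cn1ncc2cc(C(=O)NS(=O)(=O)C(F)(F)F)ccc21`, differs from compound 3 by this change: ((trifluoromethyl)sulfonyl)carbamoyl in place of (phenylcarbamoyl)amino on an aromatic carbon. The incoming group, like the carboxy group of compound 1, puts a carbonyl directly on the aromatic carbon and keeps a hydrogen-bond donor there, whereas the outgoing group of compound 3 resembles the group of compound 2, both of which gave far higher numbers than compound 1 in this assay. For the measured compounds named here, no measured step covers the incoming group itself, so the estimate leans on the contrast between compound 1 and compounds 2 and 3.

For compound 4 in this assay the expected step is therefore a 20-fold lower number from compound 3 to compound 4 (1.30 log units; beyond the scatter), a clearly lower number. The estimate for compound 4 is 300 nM, expected to lie between 60 nM and 1500 nM.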

Compound 4, half-maximal inhibitory concentration: 510 nM
The estimate for compound 4 lay 1.7-fold (0.23 log units) below the measured number; measured number inside the range.
By their numbers in this assay, from the lowest: compound 1; then compound 4; then compound 2; then compound 3.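

At this position on the shared core in this assay, a group other than carboxy that puts a carbonyl directly on the aromatic carbon also gives a lower number than the groups attached through nitrogen (a 12-fold lower number from compound 3 to compound 4 (1.07 log units; beyond the scatter); a 4.1-fold lower number from compound 2 to compound 4 (0.61 log units; beyond the scatter)). Even so, ((trifluoromethyl)sulfonyl)carbamoyl does not match the carboxy group, since replacing the hydroxy on that carbonyl carbon with ((trifluoromethyl)sulfonyl)amino gives a 9.3-fold higher number from compound 1 to compound 4 (0.97 log units; beyond the scatter). No supporting measurement is available to explain these differences.

The compounds shown leave open how much the trifluoromethyl contributes, which an acyl sulfonamide carrying a methyl or a phenyl in its place would test. A primary amide on the same aromatic carbon would show whether the sulfonyl part is needed at all.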